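This account rests on a few compounds, and the source may have more. Where it says the series, first, only, none or still open, it means among the compounds named here.

Series notes, the step from compound 3 to compound 4.

Three compounds of this set have been run in a functional assay on HepG2 cells (Homo sapiens) for antiproliferative activity, with a stated time of 72 h; on this read-out lower numbers stand for an effect already at smaller amounts and higher numbers for an effect only at larger amounts of compound. Compound 1, `COc1ccc(-c2[nH]c3cc(OC)cc(OC)c3c(=O)c2I)cc1`, comes out only as a limit of the assay, > 86200 nM. Compound 2, `COC(=O)c1cc(=O)c2c(OC)cc(OC)cc2n1C`, likewise gives only a limit, > 19000 nM. Compound 3, `COc1ccc(-c2cc(=O)c3c(OC)cc(OC)cc3n2S(=O)(=O)c2cccc([N+](=O)[O-])c2)cc1`, also reaches no measured number and stands at the limit > 39600 nM. Each of the three therefore marks one of the limits recorded in this assay: the limit of > 19000 nM in this assay, at which 1 of the 3 values shown sits, the limit of > 39600 nM in this assay, at which 1 of the 3 values shown sits, and (the limit of > 86200 nM in this assay, at which 1 of the 3 values shown sits). Compound 3 thus stands nowhere on a measured scale; its value is a limit, and the two other values shown are limits as well, so no ordering among the three can be made.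

Compound 4, `COc1ccc(-c2cc(=O)c3c(OC)cc(OC)cc3n2S(=O)(=O)c2ccc(OC)cc2)cc1`, differs from compound 3 in one place: 4-methoxyphenyl in place of 3-nitrophenyl on a sulfonyl sulfur. Within the data shown here, nothing in the measured set bears on this change: the three compounds share no single-point step with one another, and no measured number exists at all in this assay. Compound 4 is therefore expected to show a step that the limit leaves unreadable from compound 3 to compound 4, that is, no step beyond the scatter. For compound 4 in this assay the expected value is 50000 nM, with a range from 10000 nM to 200000 nM, and most likely the assay again reports only a limit.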

Compound 4, half-maximal effective concentration: > 82700 nM
Compound 4 gave a limit, no number (the forecaster's own chance of this, stated with the estimate: 80%); middle value at least 1.6-fold (0.21 log units) away from the limit.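

Among these compounds, compound 3 and compound 4 both stand at limits of the assay in this assay, so the swap of 3-nitrophenyl for 4-methoxyphenyl on a sulfonyl sulfur gives no step that can be read. The compounds shown leave open whether the group at this place has any bearing on the antiproliferative read-out in this assay.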